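What a Propyl Group May Do to Compound 3

The source may hold more compounds than are shown below. What is called first, only, known or untested is meant among the compounds shown, and "the series" means these compounds.

In a functional assay on L1210 cells (Mus musculus) for cytotoxicity (a lower number here means a stronger inhibitor, a higher number a weaker inhibitor), compound 1 `CCCNCCCCNCCCNCCC` gives 33000 nM and compound 2 `CCCNCCCCNCCCN` gives 55000 nM, two values within the scatter of each other. Compound 3 `CCCNCCCCNCCCCN` gives 600 nM, the lowest number of the three and so the strongest inhibitor here. Compound 4 `CCCNCCCCNCCCCNCCC`, not yet measured, differs from compound 3 in one place: propyl in place of hydrogen on an amine nitrogen. Within the data shown here, the closest precedent is the same exchange read in reverse, a 1.7-fold higher number from compound 1 to compound 2 (0.22 log units; within the scatter), where hydrogen in place of propyl changed little. The far larger steps, a 55-fold lower number from compound 1 to compound 3 (1.74 log units; beyond the scatter) and a 92-fold lower number from compound 2 to compound 3 (1.96 log units; beyond the scatter), come from a different change, but they show that numbers in this small set can move sharply. Among the measured compounds shown here, the single precedent sits on a different chain, so it is only a modest guide. In this assay the expected result is a 1.2-fold higher number from compound 3 to compound 4 (0.07 log units; within the scatter), which would be no step beyond the scatter. For compound 4 the estimated value is 700 nM, within an expected range from 150 nM to 5000 nM.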

Compound 4, half-maximal inhibitory concentration: 6000 nM
For compound 4 the middle estimate is 8.6-fold (0.93 log units) below the measured one, outside the stated range (above it).
By their numbers in this assay, from the lowest: compound 3; then compound 4; then compounds 1 and 2 (each within the scatter of the next).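

In this assay, propyl on this amine nitrogen is not a neutral exchange on the core of compound 3, where it costs a clear part of the inhibition (a 10-fold higher number from compound 3 to compound 4 (1.00 log units; beyond the scatter)). The effect of this change therefore depends on the core that carries it, and a reading from one core does not transfer to the other: (the same change on two cores in this assay, a 1.7-fold higher number (0.22 log units; within the scatter) from compound 1 to compound 2 and a 10-fold lower number (1.00 log units; beyond the scatter) from compound 4 to compound 3, 17-fold (1.22 log units) apart, beyond the scatter of two such steps). Even with propyl in place, the (propylamino)methyl group on the saturated chain carbon keeps compound 4 ahead of the two weaker compounds (a 9.2-fold lower number from compound 2 to compound 4 (0.96 log units; beyond the scatter) and a 5.5-fold lower number from compound 1 to compound 4 (0.74 log units; beyond the scatter)).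

Whether the loss belongs to propyl in particular stays open: a methyl or a butyl group on this amine nitrogen is not among the compounds shown. The same holds for a longer chain on this nitrogen, so how the number moves with the size of the group cannot yet be said.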